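From Isobutyl to Cyclopentyl on a Shared Core

The compounds below may be only part of what the source reports. "The series", "measured", "known", "first", "only" and "open" are said of these compounds alone.

Compounds measured so far in a functional assay on A549 cells (Homo sapiens) for antiproliferative activity, read by MTT assay, with a stated time of 72 h; on this read-out lower numbers stand for stronger inhibition and higher numbers for weaker inhibition:
- Compound 1 `CC(C)CNC(=N)NC(=N)Nc1ccc(C(F)(F)F)cc1`: 1300 nM
- Compound 2 `CC(C)CNC(=N)NC(=N)Nc1ccc(F)c(F)c1`: 2400 nM

In this assay, compound 2 gives 2400 nM and compound 1 gives 1300 nM, so these two values lie within the scatter of each other. Compound 3 `N=C(NC(=N)NC1CCCC1)Nc1ccc(F)c(F)c1` has not yet been measured. It keeps the rest of compound 2 and carries cyclopentyl in place of isobutyl on an amine nitrogen. Among the measured compounds shown here, no measured pair shows a change at this place, so the data offer no direct guide to its size. Only a small shift in this assay is expected, with no firm direction and nothing beyond the scatter. The estimate amounts to a 1.2-fold lower number from compound 2 to compound 3 (0.08 log units; within the scatter). For compound 3 the expected value is 2000 nM, with an estimated range from 900 nM to 4500 nM.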

Compound 3, half-maximal inhibitory concentration: 3500 nM
Compound 3: middle estimate off by 1.8-fold (0.24 log units), on the low side; the range from low to high includes it.
By their numbers in this assay, from the lowest: compounds 1, 2 and 3 (each within the scatter of the next, the first and the last beyond it).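

In this assay, among the compounds shown here, cyclopentyl in place of isobutyl on an amine nitrogen, the first change at this place that can be read, gives a 1.5-fold higher number from compound 2 to compound 3 (0.16 log units; within the scatter) on the core of compound 2. This place therefore accepts a five-membered carbon ring instead of the open branched chain, with one more heavy atom, and the assay does not separate the two compounds beyond the usual scatter. No measured evidence bears on why this step is so small.

As far as these compounds go, whether cyclopentyl behaves the same way on the core of compound 1 remains open. From the compounds shown here alone, it is also open how this place would respond to a longer chain such as hexyl, or to a chain ending in an amine or a carboxylic acid.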